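The source may report more compounds than this note shows. Statements on the series, on what has been measured and on what is new or still open speak of the compounds shown alone.

Three compounds share one core, a butanamide on one side of the central ring and a benzamide on the other. Compound 1 `CCCC(=O)Nc1cccc(NC(=O)c2ccccc2C)c1` carries a methyl on the benzamide ring and gives 770 nM in an assay on a cell-free system (plasma) for inhibition of proteinase-activated receptor 1 (Homo sapiens), read by flow cytometry, with a stated time of 20 min; a lower number here means a stronger inhibitor, a higher number a weaker inhibitor. Going by the values given here, compound 2 `CCCC(=O)Nc1cccc(NC(=O)c2ccccc2CC)c1` carries an ethyl there instead, and in this assay compound 2 gives 520 nM; the step of a 1.5-fold lower number from compound 1 to compound 2 (0.17 log units; within the scatter) is the only single-point change measured so far. Compound 3 `CCCC(=O)Nc1cccc(NC(=O)c2cc(C)ccc2Br)c1` has a methyl and a bromo on that ring, and in this assay compound 3 gives 480 nM, the lowest of the three numbers, though the values of compound 2 and compound 1 sit close enough that nothing separates them beyond the scatter.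

Compound 4 `CCCC(=O)Nc1cccc(NC(=O)c2cc(F)ccc2Br)c1` differs from compound 3 by fluoro in place of methyl on an aromatic carbon. Among the compounds with values here, no measured step touches this kind of exchange; the one step on record, the growth of a chain carbon from compound 1 to compound 2, stayed within the scatter, so there is no measured basis for a change beyond the scatter in this assay here either. Compound 4 is therefore expected to give about 500 nM in this assay, with a likely range from 200 nM to 1300 nM, an expected step of a 1.0-fold higher number from compound 3 to compound 4 (0.02 log units; within the scatter).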

Compound 4, half-maximal inhibitory concentration: 600 nM
Compound 4: the middle estimate sits 1.2-fold (0.08 log units) below what was measured; measured number inside the range.
By their numbers in this assay, from the lowest: compounds 3, 2, 4 and 1 (each within the scatter of the next).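

In this assay, the exchange of methyl for fluoro on this aromatic carbon, meta to a large group and para to the bromo group, comes to a 1.3-fold higher number from compound 3 to compound 4 (0.10 log units; within the scatter), so the two groups cannot be told apart at this position. Going by these compounds alone, the only earlier step concerned a saturated chain carbon, whereas this one gives the first direct reading of an exchange on the aromatic carbon itself, with the bromo group and the rest of the molecule held constant. Nothing at hand bears on what lies behind this result. 

Whether an amine, a hydroxyl or a carboxylic acid on this same aromatic carbon would shift the number beyond the scatter remains open, as methyl and fluoro are the only two groups shown there, and a single exchange says little about the position as a whole. Equally open, on these data alone, is what chloro in place of the bromo group, or a longer chain in place of the butanamide chain, would do in this assay with the fluoro kept in place.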